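This account rests on a few compounds, and the source may have more. Where it says the series, first, only, none or still open, it means among the compounds named here.

In a functional assay on MCF7 cells (Homo sapiens) for antiproliferative activity (a higher number here means a weaker inhibitor, a lower number a stronger inhibitor), compound 1 `Nc1nc(=O)n([C@H]2C=C[C@@H](CO)O2)cc1Br` reaches only a limit, > 100000 nM. Going by the values given here, compound 2 `O=c1[nH]c(=O)n([C@@H]2C=C[C@@H](CO)O2)cc1F` gives 67300 nM, the only exact number so far, so it is the sole firm reference point. Compound 3 `O=c1[nH]c(=O)n([C@@H]2C=C[C@H](CO)O2)cc1F` keeps the same atoms and bonds as compound 2, and the two differ only in configuration as drawn: the two compounds have the same atoms and bonds and differ only in configuration as drawn: 1 of 2 stereo elements differ; a stereocentre at a saturated ring carbon is drawn S in compound 2 and R in compound 3. Among the compounds with values here, no measured pair shows what such a change does here, so the expected step, a 1.0-fold higher number from compound 2 to compound 3 (0.02 log units; within the scatter), is none beyond the scatter, with neither direction favoured. The estimated value for compound 3 is 70000 nM, with an expected range from 25000 nM to 150000 nM.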

Compound 3, half-maximal inhibitory concentration: 15800 nM
Compound 3: middle estimate off by 4.4-fold (0.65 log units), on the high side; the whole stated range lies above it.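

Redrawing one stereocentre at a saturated ring carbon from S to R gives a 4.3-fold lower number from compound 2 to compound 3 (0.63 log units; beyond the scatter), the first measured step in this series. In this assay, configuration alone can therefore shift the number beyond the scatter. The step can be tied to that single stereocentre because nothing else separates the pair: the fact that compounds 2 and 3 differ only in the configuration as drawn

On these data alone, compound 1 offers only a limit, so what the same change does to it stays open: the limit of > 100000 nM in this assay, at which 1 of the 3 values shown sits. Also open is whether a carboxylic acid or a longer chain at that stereocentre would keep the lower number.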